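The compounds below may be only part of what the source reports. "The series", "measured", "known", "first", "only" and "open" are said of these compounds alone.

Of the compounds shown here, three sharing one core have been tested in an assay on membranes from HeLa cells for displacement of a labelled ligand from adenosine receptor A3 (Homo sapiens), read by scintillation counting, with a stated time of 180 min, tested at 1 uM; a higher number here means more inhibition at the concentration tested (going by the name of the read-out), a lower number less inhibition. Compound 1 `CCCOC(=O)C1=C(C)NC(=S)NC1c1ccco1` gives 1% in this assay. Compound 2 `CC1=C(C(=O)OCC(C)C)C(c2ccco2)NC(=S)N1` differs from compound 1 by methyl in place of hydrogen on a saturated chain carbon bound to two saturated chain carbons, and in this assay compound 2 gives 10%; the step is a number 9 percentage points higher from compound 1 to compound 2 (within the scatter). Compound 3 `CCCOC(=O)C1=C(C)NC(=S)NC1c1ccsc1` has a core that differs from the core of compound 1 by thiophen-3-yl in place of furan-2-yl on a saturated ring carbon, and in this assay compound 3 gives 1%; the step is no change at the digits printed from compound 1 to compound 3 (within the scatter). Compound 3 thus stands level with compound 1, both at the low end of the three numbers.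

Compound 4 `CC1=C(C(=O)OCC(C)C)C(c2ccsc2)NC(=S)N1` has not yet been measured. It differs from compound 3 by methyl in place of hydrogen on a saturated chain carbon bound to two saturated chain carbons, which is the same change, at the same place, that separates compound 1 from compound 2. For compound 4 in this assay a step of a number 7 percentage points higher from compound 3 to compound 4 (within the scatter) is expected, beside the earlier a number 9 percentage points higher from compound 1 to compound 2 (within the scatter). Going by the values given here, this expectation rests on compound 1 and compound 2 alone, because a number 9 percentage points higher from compound 1 to compound 2 (within the scatter) is the only time this change has been seen, and that step lay within the scatter. Compound 4 is therefore estimated at 8% in this assay, with a likely range from 0% to 20%.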

Compound 4, a percentage reported as inhibition, at one concentration (the size of the read-out at that concentration, not a potency): 2%
Estimate against measurement, compound 4: 6 percentage points above, within the range that was stated.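

Methyl in place of hydrogen, the change that turns propoxy into isobutoxy, gives a number 1 percentage points higher from compound 3 to compound 4 (within the scatter), and the two readings of this change do not differ beyond the scatter: the same change on two cores in this assay, a number 9 percentage points higher (within the scatter) from compound 1 to compound 2 and a number 1 percentage points higher (within the scatter) from compound 3 to compound 4, 8 percentage points apart, within the scatter of two such steps. Thiophen-3-yl in place of furan-2-yl gives a number 8 percentage points lower from compound 2 to compound 4 (within the scatter), and this change also reads alike on both cores: the same change on two cores in this assay, no change at the digits printed (within the scatter) from compound 1 to compound 3 and a number 8 percentage points lower (within the scatter) from compound 2 to compound 4, 8 percentage points apart, within the scatter of two such steps. In this assay, going by these compounds alone, neither change can be told apart from no effect on either core, so this agreement shows only that no difference between cores can be seen, not that either change has a real effect that carries over from one core to another.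

The compounds shown leave open whether a longer chain in place of isobutoxy, or an amine in place of thiophen-3-yl, would give a step beyond the scatter. If such a step appeared, it could then be tested properly whether it carries from one core to another.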